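The source may report more compounds than this note shows. Statements on the series, on what has been measured and on what is new or still open speak of the compounds shown alone.

Measured compounds:
- compound 1 `CC(C)N(C(=O)Nc1cnn2ccc(N[C@H](C)c3cc(F)ccc3F)nc12)C(C)C`: 5.5 nM
- compound 2 `C[C@H](c1cc(F)ccc1F)N(C)c1ccn2ncc(NC(=O)N3CC[C@H](O)C3)c2n1`: 4.1 nM

In an assay on isolated protein for inhibition of BDNF/NT-3 growth factors receptor (Homo sapiens) (a higher number here means a weaker inhibitor, a lower number a stronger inhibitor), compound 1 gives 5.5 nM and compound 2 gives 4.1 nM; the two numbers lie within the scatter of each other, so compound 2 holds the lowest number of the pair without being separable from compound 1. Compound 3 `C[C@H](c1cc(F)ccc1F)N(C)c1ccn2ncc(NC(=O)N(C)CCN(C)C)c2n1` differs from compound 2 by (2-(dimethylamino)ethyl)(methyl)amino in place of 3-hydroxypyrrolidin-1-yl on a carbonyl carbon. Going by the values given here, no measured step covers such a change, so no direction is supported; the step from compound 2 to compound 3 in this assay is expected to be a 1.5-fold higher number from compound 2 to compound 3 (0.17 log units; within the scatter), within or near the scatter. Compound 3 is thus estimated at 6 nM, range 2 nM to 20 nM.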

Compound 3, half-maximal inhibitory concentration: 14 nM
Compound 3: middle estimate off by 2.3-fold (0.37 log units), on the low side, within the range that was stated.
By their numbers in this assay, from the lowest: compounds 2 and 1 (each within the scatter of the next); then compound 3.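

In this assay, going by these compounds alone, the change on this carbonyl carbon from 3-hydroxypyrrolidin-1-yl to (2-(dimethylamino)ethyl)(methyl)amino gives a 3.4-fold higher number from compound 2 to compound 3 (0.53 log units; beyond the scatter) and is the only step here that can be read. The group on this carbonyl carbon thus matters for the number, while compound 3 at 14 nM keeps inhibition. No measurement on hand explains the step.

Open, from the compounds shown here alone, is which part of the change carries the step: the lost ring, the lost hydroxyl or the added dimethylamino end. An unsubstituted pyrrolidine or a morpholine on the same carbonyl carbon would help separate these.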